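Biaryl in place of nitrile on a phenylpropanoic acid

The compounds below may be only part of what the source reports. "The series", "measured", "known", "first", "only" and "open" are said of these compounds alone.

Two compounds sharing a propanoic acid on a benzyloxy-substituted core have been tested in a functional assay on 1321-N1 cells for agonist activity at Free fatty acid receptor 1 (Homo sapiens), read by calcium flux; on this read-out higher numbers stand for an effect only at larger amounts of compound and lower numbers for an effect already at smaller amounts. Compound 1 `O=C(O)CCc1ccc(OCc2ccccc2)c(I)c1` gives 12600 nM. Compound 2 `N#Cc1cccc(COc2ccc(CCC(=O)O)cc2)c1` gives 525 nM, the lower of the two numbers, and the gap to compound 1 lies beyond the usual scatter of this assay. Among the compounds with values here, the two compounds differ in more than one place, so the numbers alone show only that compound 2 acts at smaller amounts.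

Compound 3 `Cc1ccc(-c2cccc(COc3ccc(CCC(=O)O)cc3)c2)cc1` is the next compound to be measured. It follows from compound 2 by a single change: 4-methylphenyl in place of cyano on an aromatic carbon. The new group sits on an aromatic carbon, meta to a large group.

Within the data shown here, no measured pair in this set isolates such a change, so the size of the step rests on expectation only. A step from compound 2 to compound 3 of a 4.8-fold lower number from compound 2 to compound 3 (0.68 log units; beyond the scatter) is expected, toward lower numbers and beyond the scatter. Compound 3 is therefore estimated at 110 nM, within a range from 30 nM to 400 nM.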

Compound 3, half-maximal effective concentration: 490 nM
Beside the measured number, compound 3's estimate is 4.5-fold (0.65 log units) below it; measured number above the stated range.
By their numbers in this assay, from the lowest: compounds 3 and 2 (each within the scatter of the next); then compound 1.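

Replacing cyano with 4-methylphenyl on this aromatic carbon, meta to a large group, gives in this assay a 1.1-fold lower number from compound 2 to compound 3 (0.03 log units; within the scatter) and so leaves compound 2 and compound 3 indistinguishable on this read-out. Within the data shown here, this is the first pair in the set that differs in one place, and it shows that this position accepts a group of 7 heavy atoms with a six-membered aromatic ring as well as it accepts one of 2 heavy atoms with a triple bond. The compounds shown offer no measured property that would account for the two groups reading alike.

As far as these compounds go, what a plain phenyl, a methoxy group or an amine would give at this carbon stays open, as does the part played by the methyl group on the new ring. From the compounds shown here alone, the contribution of the iodo group of compound 1 also remains open, since compound 1 differs from compound 2 and compound 3 in more than one place.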